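The compounds below may be only part of what the source reports. "The series", "measured", "known", "first", "only" and "open" are said of these compounds alone.

Measured compounds:
Compound 1 `COc1cc(-c2cc(/C=C/C(=O)c3ccc(N)cc3)[nH]n2)cc(OC)c1OC` — in a functional assay on MCF7 cells (Homo sapiens) for inhibition, read by MTT assay, with a stated time of 48 h (on this read-out higher numbers stand for weaker inhibition and lower numbers for stronger inhibition), compound 1 gives 1600 nM.
Compound 2 `COc1cc(-c2cc(/C=C/C(C)=O)[nH]n2)cc(OC)c1OC` — in this assay compound 2 gives 20100 nM.

Within the data shown here, compound 2 stands highest of the two numbers; its nearest neighbour is compound 1, and the only step known is a 13-fold higher number from compound 1 to compound 2 (1.10 log units; beyond the scatter). The unmeasured compound 3 `COc1cc(-c2cc(/C=C/C(=O)c3ccc(Cl)cc3)[nH]n2)cc(OC)c1OC` differs from compound 2 in one place: 4-chlorophenyl in place of methyl on a carbonyl carbon. Among the measured compounds shown here, this is the mirror of the one measured step, in that an aromatic ring again takes the place of the methyl on the carbonyl carbon, though the ring now bears chlorine where compound 1 bears an amino group. For the measured compounds named here, only the step from compound 1 to compound 2 bears on this change, and it was large; a step of similar size in the opposite direction is therefore expected for compound 3, with the caveat that nothing measured here separates a 4-chlorophenyl from a 4-aminophenyl. Compound 3 is expected to show an 8.0-fold lower number from compound 2 to compound 3 (0.91 log units; beyond the scatter). The estimated value of compound 3 in this assay is 2500 nM, within a range of 800 nM to 8000 nM.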

Compound 3, half-maximal inhibitory concentration: 11600 nM
The estimate for compound 3 lay 4.6-fold (0.67 log units) below the measured number; measured number outside the range, above it.
By their numbers in this assay, from the lowest: compound 1; then compounds 3 and 2 (each within the scatter of the next).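

Putting 4-chlorophenyl on the carbonyl carbon in place of methyl gives a 1.7-fold lower number from compound 2 to compound 3 (0.24 log units; within the scatter) in this assay, so an aromatic ring at this place does not by itself bring a change beyond the scatter. Chloro in place of amino on the aromatic carbon gives a 7.3-fold higher number from compound 1 to compound 3 (0.86 log units; beyond the scatter) in the same assay, which shows that, among these three compounds, the large gap between compound 1 and compound 2 appears only with the 4-aminophenyl group and not with every phenyl ring on the carbonyl carbon. No measurement is at hand that would explain why the amino compound stands apart from the chloro compound.

Going by these compounds, how a hydroxyl, dimethylamino or acetylamino group on that aromatic carbon would compare with amino and chloro remains open, so it cannot yet be said whether the lower number of compound 1 is particular to the amino group. Also open, on these data alone, is where an unsubstituted phenyl on the carbonyl carbon would fall, and so whether chloro or amino is the group that moves the number away from that of the bare ring.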